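The source may report more compounds than this note shows. Statements on the series, on what has been measured and on what is new or still open speak of the compounds shown alone.

In an ADME assay on PBMC cells (Homo sapiens) for cytotoxicity, read by trypan blue exclusion, with a stated time of 6 days (on this read-out higher numbers stand for lower toxicity in this test and lower numbers for higher toxicity in this test), compound 2 `C[C@@]1(O)[C@H](O)[C@@H](CO)O[C@H]1n1cnc2c(N)nc(N=[N+]=[N-])nc21` gives > 100000 nM, which is a limit of the assay rather than a number. Compound 1 `CONc1nc(N)nc2c1ncn2[C@@H]1O[C@H](CO)[C@@H](O)[C@@]1(C)O` gives > 100000 nM in this assay, again a limit. Compound 3 `COc1nc(ONC(=O)OCc2ccccc2)nc2c1ncn2[C@@H]1O[C@H](CO)[C@@H](O)[C@@]1(C)O` gives > 100000 nM there, also a limit. Among the measured compounds shown here, as the limit of > 100000 nM in this assay, at which 3 of the 3 values shown sit, records, every value so far sits at that limit, so compound 2 stands level with the others. Compound 4 `CONc1nc(N)c2ncn([C@@H]3O[C@H](CO)[C@@H](O)[C@@]3(C)O)c2n1` has not yet been measured; it differs from compound 2 by methoxyamino in place of azido on an aromatic carbon. For the measured compounds named here, no step between measured compounds is available. Compound 1 already bears a methoxyamino group and gives only the limit > 100000 nM in this assay. Compound 4 is therefore expected to show no step beyond the scatter, a number no higher from compound 2 to compound 4 (the limit leaves the size open) being the expected step. Compound 4 is estimated at 100000 nM, between 50000 nM and 300000 nM.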

Compound 4, half-maximal cytotoxic concentration: > 100000 nM
Compound 4 ended at the assay's limit (the forecaster's own chance of this, stated with the estimate: 85%); the middle value sits exactly at the limit.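

In this assay, compound 2 and compound 4 both stand at the assay's limit rather than at a number, and no step can be read between them. The compounds shown leave open at what concentration any of them would become toxic in this test: the limit of > 100000 nM in this assay, at which 4 of the 4 values shown sit.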